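A few compounds are considered here, and "the series" means these few. Any claim that something is new, unique, unknown or untested is made for them only; others in the source may bear on it.

Compound 1, `Cc1nc(N)sc1CCCN/C(N)=N/C(=O)NC(C)c1ccc(Br)cc1`, was tested in a functional assay on Right cardiac atrium for agonist activity at histamine H2 receptor (Cavia porcellus), with a stated time of 30 min, in the presence of a further agent that is not named here; on this read-out lower numbers stand for smaller maximal responses and higher numbers for larger maximal responses. There compound 1 gives 0.87, the higher of the two numbers recorded so far. Going by the values given here, the only other measured compound, compound 2 with structure `Cc1nc(N)sc1CCCN/C(N)=N/C(=S)NC(c1ccccc1)c1ccccc1`, gives 0.67 in this assay, a result that sits below that of compound 1 by more than the usual scatter of repeated measurements. Among the compounds with values here, compound 2 differs from compound 1 in more than one place, so no single structural step links the two.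

Compound 3, `Cc1nc(N)sc1CCCN/C(N)=N/C(=O)NC(C)c1ccco1`, has not yet been measured. It differs from compound 1 by furan-2-yl in place of 4-bromophenyl on a saturated chain carbon bound to an amide-type nitrogen and a saturated chain carbon. The rest of the shared core is kept. Within the data shown here, no measured pair traces this kind of swap, so its size is open; the expectation is that one aromatic ring replacing another here changes the maximal response little, with the step a number 0.020 lower from compound 1 to compound 3 (within the scatter) expected to stay within the scatter. Compound 3 is therefore estimated at 0.85, with a range from 0.65 to 1.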

Compound 3, intrinsic activity: the largest response reached, as a fraction of the reference agonist's: 1
Compound 3: the middle estimate sits 0.15 below what was measured, within the range that was stated.
By their numbers in this assay, from the lowest: compound 2; then compound 1; then compound 3.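

Going by these compounds alone, compound 3 gives the first one-place comparison in this set, and it shows that this saturated chain carbon does not need the 4-bromophenyl group to keep a large maximal response. In this assay, the change to furan-2-yl gives a step a number 0.13 higher from compound 1 to compound 3 (beyond the scatter), so a five-membered aromatic ring with 1 hetero atom serves here at least as well as the six-membered ring of carbon only. Nothing measured here accounts for this rise.

The compounds shown leave open whether the rise goes with the ring oxygen, the smaller ring or the loss of bromine, and a plain phenyl or a thiophen-2-yl group at this place would help to separate these. Going by these compounds, how a saturated ring such as cyclohexyl would behave here also remains open.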